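Fluoro on the pendant phenyl of the methoxy analogue

The source may hold more compounds than are shown below. What is called first, only, known or untested is meant among the compounds shown, and "the series" means these compounds.

Compound 1 `O=C(Nc1nc2ccc(Cl)cc2s1)c1cn(-c2ccccc2)nc1-c1ccccc1` gives 3690 nM in a functional assay on PC-3 cells (Homo sapiens) for cytotoxicity, read by MTT assay, with a stated time of 72 h; a higher number here means a weaker inhibitor, a lower number a stronger inhibitor. Going by the values given here, compound 2 `COc1ccc2nc(NC(=O)c3cn(-c4ccccc4)nc3-c3ccccc3)sc2c1` gives 17500 nM and stands highest of the two numbers so far; the only measured step, a 4.7-fold higher number from compound 1 to compound 2 (0.68 log units; beyond the scatter), is methoxy in place of chloro on an aromatic carbon. Compound 3 `COc1ccc2nc(NC(=O)c3cn(-c4ccccc4)nc3-c3ccc(F)cc3)sc2c1` differs from compound 2 by fluoro in place of hydrogen on an aromatic carbon. No measured step touches this ring, so nothing shown speaks for a shift in either direction, and the expected step of a 1.0-fold lower number from compound 2 to compound 3 (0.01 log units; within the scatter) is none beyond the scatter. Compound 3 is therefore estimated at 17000 nM, within 7000 nM to 40000 nM.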

Compound 3, half-maximal inhibitory concentration: 12800 nM
Beside the measured number, compound 3's estimate is 1.3-fold (0.12 log units) above it; measured number inside the range.
By their numbers in this assay, from the lowest: compound 1; then compounds 3 and 2 (each within the scatter of the next).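

In this assay, going by these compounds alone, the first measured change on this ring, phenyl to 4-fluorophenyl, gives a 1.4-fold lower number from compound 2 to compound 3 (0.14 log units; within the scatter). A single fluoro at this carbon therefore leaves the cytotoxicity reading of the methoxy analogue unresolved from that of compound 2, with no shift that can be read. No other data bear on this result.

From the compounds shown here alone, whether an amine or a trifluoromethyl group at this carbon would give a step beyond the scatter remains open. Also open, going by these compounds, is whether fluoro gives the same step on the chloro compound 1.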